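A Single Methyl Added to the Core of Compound 3

The compounds below may be only part of what the source reports. "The series", "measured", "known", "first", "only" and "open" are said of these compounds alone.

Compound 1, `COc1ccccc1-c1cc(O)c2cc(C)cnc2n1`: 19500 nM
Compound 2, `COc1cccc(-c2cc(O)c3c(C)cc(C)nc3n2)c1`: 251 nM
Compound 3, `COc1cccc(-c2cc(O)c3cccnc3n2)c1`: 55 nM

In a functional assay on OVCAR-3 cells (Homo sapiens) (a higher number here means a weaker inhibitor of growth, a lower number a stronger inhibitor of growth), compound 3 gives the lowest of the three numbers. For the measured compounds named here, the number for compound 2 lies beyond the usual scatter above it, and that for compound 1 lies far beyond it, so compound 3 is the strongest growth inhibitor of the three measured so far.

Compound 4, `COc1cccc(-c2cc(O)c3c(C)ccnc3n2)c1`, has not yet been measured. It differs from compound 3 in one place only: methyl in place of hydrogen on an aromatic carbon. The core is otherwise that of compound 3, and the aryl group is the same.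

Going by the values given here, no pair of measured compounds differs in a single place, so no measured step can be drawn on directly. What the numbers do show is that compound 2, which carries two methyl groups on the same core, gives 251 nM, while compound 3 without them gives 55 nM. One methyl entering is therefore expected to raise the number in this assay by a modest step, a 2.0-fold higher number from compound 3 to compound 4 (0.30 log units; within the scatter), possibly no more than the scatter. Compound 4 is estimated at 110 nM, within a range from 35 nM to 400 nM.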

Compound 4, concentration for 50% growth inhibition: 25.7 nM
Compound 4: the middle estimate sits 4.3-fold (0.63 log units) above what was measured; measured number below the stated range.
By their numbers in this assay, from the lowest: compound 4; then compound 3; then compound 2; then compound 1.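

In this assay, methyl in place of hydrogen on an aromatic carbon, opposite the ring nitrogen, strengthens growth inhibition, with a 2.1-fold lower number from compound 3 to compound 4 (0.33 log units; beyond the scatter) as a modest step, so this position takes the group without loss. The further methyl of compound 2 works the other way: replacing it with hydrogen gives a 9.8-fold lower number from compound 2 to compound 4 (0.99 log units; beyond the scatter), so the two methyl groups of compound 2 do not count alike and the weaker number of compound 2 cannot be laid on the methyl opposite the ring nitrogen. Nothing available here accounts for either step.

Going by these compounds, whether an ethyl group, a chlorine or an amine at this position would lower the number further remains open. So does whether the methyl step would hold with a different aryl group on the shared core.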